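A few compounds are considered here, and "the series" means these few. Any claim that something is new, unique, unknown or untested is made for them only; others in the source may bear on it.

Measured so far in a functional assay on HCT-116 cells (Homo sapiens) for antiproliferative activity, read by sulforhodamine B assay, with a stated time of 72 h (a lower number here means a stronger inhibitor, a higher number a weaker inhibitor), as follows:
- compound 1 `Cn1ncc(Cl)c1-c1cc(C(=O)N[C@@H]2CN[C@H](CCNS(C)(=O)=O)C[C@H]2c2ccc(F)c(F)c2)oc1Cl` gives 920 nM
- compound 2 `Cn1ncc(Cl)c1-c1cc(C(=O)N[C@@H]2CN[C@H](CCCO)C[C@H]2c2ccc(Cl)c(Cl)c2)oc1Cl` gives 510 nM
- compound 3 `Cn1ncc(Cl)c1-c1cc(C(=O)N[C@@H]2CNCC[C@H]2c2ccc(C(F)(F)F)cc2)oc1Cl` gives 280 nM

Compound 1 stands at the upper end of these three numbers, level with compound 2 within the scatter. Compound 3 gives a lower number than compound 1, and that gap lies beyond the scatter.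

Compound 4 `Cn1ncc(Cl)c1-c1cc(C(=O)N[C@@H]2CN[C@H](CCO)C[C@H]2c2ccc(F)c(F)c2)oc1Cl` is next to be read against compound 1. It has hydroxy in place of methanesulfonamido on a saturated chain carbon, two bonds along the chain from a saturated ring carbon, so that 2-(methanesulfonamido)ethyl becomes 2-hydroxyethyl.

Within the data shown here, no two measured compounds differ in one place only, so no measured step speaks to this change directly. Compound 2 also carries a hydroxy on its chain, and at 510 nM it stays within the scatter of compound 1, although the two differ in more than one place. This is thin support, and the expectation in this assay is therefore no step beyond the scatter, with any drift toward a lower number. The expected change is a 1.3-fold lower number from compound 1 to compound 4 (0.12 log units; within the scatter) on this estimate. For compound 4 the estimated value is 700 nM with an expected range from 300 nM to 1600 nM in this series.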

Compound 4, half-maximal inhibitory concentration: 360 nM
Beside the measured number, compound 4's estimate is 1.9-fold (0.29 log units) above it; measured number inside the range.
By their numbers in this assay, from the lowest: compounds 3, 4, 2 and 1 (each within the scatter of the next, the first and the last beyond it).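

In this assay the series now has its first step that differs in one place only: on a saturated chain carbon, two bonds along the chain from a saturated ring carbon, hydroxy in place of methanesulfonamido gives a 2.6-fold lower number from compound 1 to compound 4 (0.41 log units; beyond the scatter) with the rest of compound 1 unchanged. The number therefore responds to the group at this position, and the methanesulfonamido group is not needed to hold activity here, since 2-hydroxyethyl gives the lower number of this pair. No measurement shown bears on what lies behind this step.

This single pair does not separate a gain from the hydroxy itself from a gain from losing the methanesulfonamido group, and a methoxy, a primary amine, a carboxylic acid or an acetamido group on the same chain would help to tell these apart. Also open is whether the step holds with the other substituents on the phenyl ring, as the compounds shown offer no matching pair for that, and whether a longer chain ending in hydroxy keeps the same number on the core of compound 4.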